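A few compounds are considered here, and "the series" means these few. Any claim that something is new, unique, unknown or untested is made for them only; others in the source may bear on it.

Measured compounds:
compound 1 `N=C(N)c1ccc2cc(-c3ccc(OCCCOc4ccccc4)cc3)oc2c1` with 8600 nM in an ADME assay on L6 cells (Rattus norvegicus) for cytotoxicity, read by resazurin assay, with a stated time of 70 h; a higher number here means a weaker inhibitor, a lower number a stronger inhibitor
compound 2 `c1ccc(OCCCOc2ccc(-c3cc4ccc(C5=NCCN5)cc4o3)cc2)cc1` with 16800 nM in this assay

Among the compounds with values here, only two compounds have been measured in this assay so far, and compound 1 and compound 2 lie within the usual scatter of each other: the step of a 2.0-fold higher number from compound 1 to compound 2 (0.29 log units; within the scatter) is too small to count as a real difference. Compound 1 therefore has no established place above or below any other compound here.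

Compound 3 `N=C(N)c1ccc2cc(-c3ccc(OCCCCCOc4ccccc4)cc3)oc2c1` is the next compound to be measured. It differs from compound 1 in one place only: 2-phenoxyethyl in place of phenoxy on a saturated chain carbon, three bonds along the chain from an oxygen on an aromatic ring. In plain terms, the chain that links the two aromatic rings of the shared core is made longer by two saturated carbons, and nothing else changes.

Within the data shown here, no measured step bears on this change. Among the measured compounds shown here, the single step available, from compound 1 to compound 2, alters the group on the aromatic carbon at the other end of the molecule and leaves the chain untouched, so it says nothing about chain length. With no evidence for a shift in either direction, the expectation is a step of no more than the scatter, a 1.2-fold higher number from compound 1 to compound 3 (0.07 log units; within the scatter). Compound 3 is thus estimated at 10000 nM, with a range from 4000 nM to 25000 nM.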

Compound 3, half-maximal inhibitory concentration: 9000 nM
Beside the measured number, compound 3's estimate is 1.1-fold (0.05 log units) above it; the measured number falls inside the stated range.
By their numbers in this assay, from the lowest: compounds 1, 3 and 2 (each within the scatter of the next).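

Within the data shown here, a step of a 1.0-fold higher number from compound 1 to compound 3 (0.02 log units; within the scatter) in this assay gives the first reading on the chain that links the two aromatic rings of the shared core, and it means that the longer chain cannot be told apart from the shorter one. So, on a saturated chain carbon, three bonds along the chain from an oxygen on an aromatic ring, 2-phenoxyethyl and phenoxy give numbers that this assay does not separate, at least for this pair and with the amidine-bearing end of compound 1 kept in place. No measurement at hand offers a reason for this result.

The compounds shown cover only these two chain lengths, so it remains open whether a much longer chain, a shorter chain, or a chain carrying an amine or a carboxylic acid would give a number beyond the scatter. As far as these compounds go, it is also open whether the same lengthening would read the same way with the five-membered non-aromatic ring of compound 2 at the other end of the molecule.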